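Working notes: from compound 2 to compound 3

A few compounds are considered here, and "the series" means these few. Any claim that something is new, unique, unknown or untested is made for them only; others in the source may bear on it.

- compound 1 `CCCCCCCCCCCC[C@@H](O)[C@H]1CC[C@H]([C@H](O)CCCCCCCCCCNC(=O)c2ccnn2C)O1`: 10 nM
- compound 2 `CCCCCCCCCCCC[C@@H](O)[C@H]1CC[C@H]([C@H](O)CCCCCCCCCCN(C)C(=O)c2ccnn2C)O1`: 794 nM

Both values come from a functional assay on HCT-116 cells (Homo sapiens) for inhibition, read by sulforhodamine B assay, with a stated time of 48 h; on this read-out lower numbers stand for stronger inhibition of growth and higher numbers for weaker inhibition of growth. Compound 2, at 794 nM, holds the higher of the two numbers and so shows the weaker inhibition of growth of this pair. Among the measured compounds shown here, the only measured step ends at it: a 79-fold higher number from compound 1 to compound 2 (1.90 log units; beyond the scatter), with methyl in place of hydrogen on an amide-type nitrogen.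

Next in the series is compound 3 `CCCCCCCCCCCC[C@@H](O)[C@H]1CC[C@H]([C@H](O)CCCCCCCCCCNCc2ccnn2C)O1`, with this difference: ((1-methyl-1H-pyrazol-5-yl)methyl)amino in place of methyl((1-methyl-1H-pyrazol-5-yl)carbonyl)amino on a saturated chain carbon, ten or more bonds along the chain from an oxygen on a saturated carbon and a saturated ring carbon. Its nitrogen carries hydrogen, as in compound 1, so the step of a 79-fold higher number from compound 1 to compound 2 (1.90 log units; beyond the scatter) is the one that bears on it, read in reverse. For the measured compounds named here, the carbonyl is also absent from compound 3, however, and no measured compound shows what its removal does. Only part of the large step is therefore expected to be regained, and the uncertainty is wide. The step expected in this assay is a 7.9-fold lower number from compound 2 to compound 3 (0.90 log units; beyond the scatter), towards stronger inhibition of growth. For compound 3 the estimated value is 100 nM, with an expected range of 15 nM to 600 nM.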

Compound 3, concentration for 50% growth inhibition: 1100 nM
Beside the measured number, compound 3's estimate is 11-fold (1.04 log units) below it; measured number above the stated range.
By their numbers in this assay, from the lowest: compound 1; then compounds 2 and 3 (each within the scatter of the next).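

In this assay, (1-methyl-1H-pyrazol-5-yl)methyl in place of (1-methyl-1H-pyrazol-5-yl)carbonyl on the amine nitrogen gives a 110-fold higher number from compound 1 to compound 3 (2.04 log units; beyond the scatter), so at this position the carbonyl matters even with the hydrogen on the nitrogen kept, which compound 2 alone could not show. The other new step, a 1.4-fold higher number from compound 2 to compound 3 (0.14 log units; within the scatter), means that the amide with methyl on its nitrogen and the amine with hydrogen on its nitrogen cannot be told apart in this read-out, so having the hydrogen without the carbonyl brings no measurable return towards compound 1. Of these three compounds, only compound 1, which holds both the carbonyl and the hydrogen on the nitrogen, stands at 10 nM, and the absence of either one goes with a large step.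

Still open, on these data alone, is whether the carbonyl itself is required or whether a sulfonamide or a urea at the same place, keeping the hydrogen on the nitrogen, would stay close to compound 1. The data at hand offer no explanation for either large step.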